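Notes on replacing chloro with trifluoromethoxy in the series

The source may hold more compounds than are shown below. What is called first, only, known or untested is meant among the compounds shown, and "the series" means these compounds.

Measured in a functional assay on A549 cells (Homo sapiens) for antiproliferative activity, read by MTT assay; a lower number here means a stronger inhibitor, a higher number a weaker inhibitor:
- compound 1 `Cn1c(=O)c(=O)n(C2CCCC2)c2nc(N/N=C/c3ccc(Cl)cc3)ncc21`: 6890 nM
- compound 2 `Cn1c(=O)c(=O)n(C2CCCC2)c2nc(N/N=C/c3ccc(F)cc3Br)ncc21`: 6590 nM

For the measured compounds named here, compound 1 lies within the scatter of compound 2, the only other measured compound. Compound 3 `Cn1c(=O)c(=O)n(C2CCCC2)c2nc(N/N=C/c3ccc(OC(F)(F)F)cc3)ncc21` is not yet measured. It carries trifluoromethoxy in place of chloro on an aromatic carbon, para to a large group: trifluoromethoxy in place of chloro on an aromatic carbon. Going by the values given here, the only measured step, a 1.0-fold lower number from compound 1 to compound 2 (0.02 log units; within the scatter), also changes substituents on that ring and stays within the scatter. It is a single step, so it offers limited guidance. No change beyond the scatter is therefore expected in this assay. The estimated step is a 1.1-fold lower number from compound 1 to compound 3 (0.06 log units; within the scatter). Compound 3 is expected at 6000 nM, with an estimated range of 2500 nM to 14000 nM.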

Compound 3, half-maximal inhibitory concentration: 12900 nM
Estimate against measurement, compound 3: 2.2-fold (0.33 log units) below, within the range that was stated.
By their numbers in this assay, from the lowest: compounds 2, 1 and 3 (each within the scatter of the next).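

In this assay, trifluoromethoxy in place of chloro on an aromatic carbon, para to a large group, gives a 1.9-fold higher number from compound 1 to compound 3 (0.27 log units; within the scatter). This position therefore accepts a substituent of five heavy atoms, carrying a hydrogen-bond acceptor, in place of a single chlorine without a step beyond the scatter, which the earlier halogen-only comparison could not show. Nothing available explains this result.

Going by these compounds, whether an amine or a carboxylic acid at this position would also stay within the scatter remains open. So does whether any substituent here can move the number beyond the scatter.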